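Swapping a Trifluoromethylphenyl for Benzyl on Silicon

This account rests on a few compounds, and the source may have more. Where it says the series, first, only, none or still open, it means among the compounds named here.

Three measured compounds share one core and differ in the group attached to a silicon and in the unsaturated chain on the amine nitrogen. In a functional assay on liver (Sus scrofa) for inhibition of squalene monooxygenase (Homo sapiens), using microsomes (on this read-out higher numbers stand for weaker inhibition and lower numbers for stronger inhibition), compound 3 `CCN(C/C=C/C#CC(C)(C)C)Cc1cccc(OC[Si](C)(C)c2ccccc2C(F)(F)F)c1` gives 70 nM. Compound 1 `CCN(CC#CC#CC(C)(C)OC)Cc1cccc(OC[Si](C)(C)c2ccccc2C)c1` gives 70 nM, and the two stand level. Going by the values given here, compound 2 `CCN(C/C=C/C#CC(C)(C)C)Cc1cccc(OC[Si](C)(C)c2cccc(C)c2)c1` gives 3000 nM; the step of a 43-fold lower number from compound 2 to compound 3 (1.63 log units; beyond the scatter) is the only change within the set made at the silicon alone. Compound 4 `CCN(C/C=C/C#CC(C)(C)C)Cc1cccc(OC[Si](C)(C)Cc2ccccc2)c1` has not yet been measured; it differs from compound 3 by benzyl in place of 2-(trifluoromethyl)phenyl on a silicon. Among the compounds with values here, the single measured step at the silicon shows that this group can shift the number a great deal, but benzyl appears nowhere among the measured compounds, so no step covers it directly. Within the data shown here, the expected step of a 7.1-fold higher number from compound 3 to compound 4 (0.85 log units; beyond the scatter) is a weakening, smaller than the one measured step and uncertain in size. For compound 4 the estimate in this assay is 500 nM, with a range from 70 nM to 5000 nM.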

Compound 4, half-maximal inhibitory concentration: 130 nM
Beside the measured number, compound 4's estimate is 3.8-fold (0.59 log units) above it, within the range that was stated.
By their numbers in this assay, from the lowest: compounds 1, 3 and 4 (each within the scatter of the next); then compound 2.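

In this assay, benzyl in place of 2-(trifluoromethyl)phenyl on the silicon gives a 1.9-fold higher number from compound 3 to compound 4 (0.27 log units; within the scatter) and so cannot be told apart from it. The same benzyl set against 3-methylphenyl gives a 23-fold lower number from compound 2 to compound 4 (1.36 log units; beyond the scatter) as its large step. Among compounds 2, 3 and 4, which share one chain on the nitrogen, only compound 2 stands apart, and compound 4 shows that a group without fluorine can reach the level of compound 3.

From the compounds shown here alone, it remains open whether 2-phenylethyl on the silicon, with a longer chain to its ring than benzyl, or a benzyl ring carrying an amine would stay at this level. Nothing shown here explains why these groups on the silicon give the numbers they do.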